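The compounds below may be only part of what the source reports. "The series", "measured", "known", "first", "only" and "open" are said of these compounds alone.

Of the compounds shown here, two have so far been measured in a functional assay on CHO cells for antagonist activity at adenosine receptor A2b (Homo sapiens), read by 33P incorporation, with a stated time of 20 min; on this read-out higher numbers stand for weaker inhibition and lower numbers for stronger inhibition. Compound 1, `Cn1c(-c2cccc(Cl)c2)nc2c(NC3CCCC3)ncnc21`, carries a 3-chlorophenyl on its core and a cyclopentylamino group; in this assay compound 1 gives 2530 nM. Compound 2, `CCn1c(-c2ccccc2)nc2c(N)ncnc21`, carries a phenyl without chlorine, an ethyl on the ring nitrogen and a simple amino group; in this assay compound 2 gives 3020 nM. These two numbers lie within the usual scatter of each other, so compound 1 stands alongside compound 2 rather than apart from it, and neither can be called the stronger.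

Compound 3, `Cn1c(-c2ccc(Cl)cc2)nc2c(NC3CCCC3)ncnc21`, is the next compound to be measured. It differs from compound 1 in a single way: 4-chlorophenyl in place of 3-chlorophenyl on an aromatic carbon. For the measured compounds named here, no pair of measured compounds shows a step of this kind, so the data give no direct hint of how much exchanging one chlorophenyl for the other matters.

The expectation is that the step from compound 1 to compound 3 will be small, no larger than the scatter, and a 1.0-fold lower number from compound 1 to compound 3 (0.01 log units; within the scatter) is the estimate. Compound 3 is expected to give about 2500 nM, with a range from 1000 nM to 6500 nM.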

Compound 3, inhibition constant: > 30000 nM
Compound 3: only a limit was reported; the forecaster's own chance of this, stated with the estimate: 5%; at least 12-fold (1.07 log units) between middle value and limit.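

Exchanging 3-chlorophenyl for 4-chlorophenyl, on the aromatic carbon between two ring nitrogen atoms, gives an at least 11-fold higher number from compound 1 to compound 3 (1.07 log units; beyond the scatter). In this assay compound 3 gives > 30000 nM, and this is a limit of the assay rather than a number, so the step has a lower bound but no known full size. The earlier compounds differ from each other in several places and could show nothing of this kind, whereas here a single change between two groups with the same heavy atoms, the same ring and the same count of hydrogen-bond donors and acceptors is enough to separate a measured number from the limit, and the one piece of evidence on this result is just that limit: the limit of > 30000 nM in this assay, at which 1 of the 3 values shown sits.

Why the two chlorophenyl groups part so sharply cannot be told from these compounds, and with the cyclopentylamino group in place there is no plain phenyl to show what the chlorine contributes on its own. From the compounds shown here alone, it also remains open whether a 3-methoxyphenyl or a 3-fluorophenyl would behave like compound 1, and whether a 4-methoxyphenyl or a 4-fluorophenyl would behave like compound 3.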